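This account rests on a few compounds, and the source may have more. Where it says the series, first, only, none or still open, it means among the compounds named here.

Measured so far:
- compound 1 `CC1=C(/C=C/C(C)=C/C=C/C(C)=C\C(=O)Nc2cccc(F)c2)C(C)(C)CCC1n1ccnc1`: 6760 nM
- compound 2 `CC1=C(/C=C/C(C)=C/C=C/C(C)=C\C(=O)Nc2ccccc2)C(C)(C)CC=C1c1cncnc1`: 22900 nM

In a functional assay on MDA-MB-468 cells (Homo sapiens) for inhibition, read by MTT assay (on this read-out lower numbers stand for stronger inhibition of growth and higher numbers for weaker inhibition of growth), compound 1 gives the lower of the two numbers at 6760 nM, and compound 2 gives a higher number at 22900 nM, a gap beyond the scatter. These two compounds differ in more than one place, so their gap says nothing about any single change.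

Next is compound 3 `CC1=C(/C=C/C(C)=C/C=C/C(C)=C\C(=O)NCc2ccccc2)C(C)(C)CCC1n1ccnc1`, with benzyl in place of 3-fluorophenyl on an amide-type nitrogen. Within the data shown here, no measured pair isolates this change, so the expectation stays anchored on compound 1 at 6760 nM, with a wide range. In this assay, a small move towards weaker inhibition of growth is expected, probably not beyond the scatter. The expected step is a 1.3-fold higher number from compound 1 to compound 3 (0.12 log units; within the scatter). The estimate for compound 3 is 9000 nM, with an expected range of 3500 nM to 25000 nM.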

Compound 3, concentration for 50% growth inhibition: 7240 nM
Estimate against measurement, compound 3: 1.2-fold (0.09 log units) above; the range from low to high includes it.
By their numbers in this assay, from the lowest: compounds 1 and 3 (each within the scatter of the next); then compound 2.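

In this assay, among these compounds, benzyl in place of 3-fluorophenyl on an amide-type nitrogen gives a 1.1-fold higher number from compound 1 to compound 3 (0.03 log units; within the scatter), the only comparison so far in which a single place differs. At this position, then, the 3-fluorophenyl group can give way to benzyl with no read-out difference beyond the scatter, although the fluorine leaves and the ring no longer sits directly on the nitrogen. Nothing on hand accounts for this result.

This single exchange does not show how far the position's tolerance extends, since both groups carry one six-membered aromatic ring of carbon only. A longer chain such as phenethyl in place of benzyl, or an amine or a carboxylic acid on the benzyl ring, remains an open test of that tolerance.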